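This account rests on a few compounds, and the source may have more. Where it says the series, first, only, none or still open, it means among the compounds named here.

Measured in an ADME assay on microsomes from liver (Homo sapiens) for metabolic stability, read by LC-MS, using NADPH, with a stated time of 30 min, tested at 3 uM; on this read-out lower numbers stand for a less stable compound and higher numbers for a more stable compound:
- Compound 1 `COc1ncc(-c2ccc(-c3cnc4c(c3)CN(C)C4=O)s2)cc1NS(=O)(=O)c1ccccc1[N+](=O)[O-]`: 94%
- Compound 2 `COc1ncc(-c2ccc(-c3cnc4c(c3)CN(C)C4=O)s2)cc1NS(=O)(=O)c1ccc(F)cc1F`: 75%

Compound 2 holds the lower of these two numbers. Compound 3 `COc1ncc(-c2ccc(-c3cnc4c(c3)CN(C)C4=O)s2)cc1NS(=O)(=O)c1ccccc1C(F)(F)F` differs from it by 2-(trifluoromethyl)phenyl in place of 2,4-difluorophenyl on a sulfonyl sulfur. For the measured compounds named here, one measured step bears on this change, at the same sulfonyl sulfur: a number 19 percentage points lower from compound 1 to compound 2 (beyond the scatter). Going by the values given here, no measurement yet covers 2-(trifluoromethyl)phenyl itself, so this single step is only a weak guide. In this assay, a modest rise is expected, a number 8 percentage points higher from compound 2 to compound 3 (within the scatter). For compound 3 the estimate is 83%, with an expected range of 67% to 96%.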

Compound 3, percent of the compound remaining: 63%
Compound 3: the middle estimate sits 20 percentage points above what was measured, and the stated range ends above it.
By their numbers in this assay, from the lowest: compound 3; then compound 2; then compound 1.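

In this assay the group on the sulfonyl sulfur still moves the number when one fluorine-bearing group replaces another: 2-(trifluoromethyl)phenyl in place of 2,4-difluorophenyl gives a number 12 percentage points lower from compound 2 to compound 3 (beyond the scatter) and so the presence of fluorine alone does not settle the result. Trifluoromethyl in place of nitro on an aromatic carbon gives a number 31 percentage points lower from compound 1 to compound 3 (beyond the scatter) and this is the largest step shown at this position. No measurement here gives a reason for either step. On these data alone, whether a plain phenyl, or a phenyl carrying an amine or a carboxylic acid, would fall nearer compound 1 or compound 3 remains open.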